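This account rests on a few compounds, and the source may have more. Where it says the series, first, only, none or still open, it means among the compounds named here.

In an in vivo ADME assay on the whole organism (strain BALB/C) for metabolic stability, with Mus musculus as the target, read by LC-MS (on this read-out higher numbers stand for a longer-lived compound and lower numbers for a shorter-lived compound), compound 1 (`CN1C[C@H](C(=O)Nc2ccc(F)c(F)c2)[C@@H](c2ccc(/C=C/C(=O)Nc3ccccc3N)cc2)C1`) gives 4 h and compound 2 (`CC(C)(C)N1C[C@H](C(=O)Nc2ccc(Cl)cc2)[C@@H](c2ccc(/C=C/C(=O)Nc3ccccc3N)cc2)C1`) gives 6.8 h, two values that lie within the usual scatter of each other. Compound 3 (`Nc1ccccc1NC(=O)/C=C/c1ccc([C@H]2CN(C3CCOCC3)C[C@@H]2C(=O)Nc2ccc(Cl)cc2)cc1`) differs from compound 2 at one place, with oxan-4-yl in place of tert-butyl on an amine nitrogen in a ring. Going by the values given here, no pair of measured compounds shows what a change of this kind does, so no shift beyond the scatter is expected in this assay. The expected step is a 1.4-fold lower number from compound 2 to compound 3 (0.13 log units; within the scatter). For compound 3 the estimated half-life is 5 h, with an expected range of 2.2 h to 11 h.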

Compound 3, half-life: 4.9 h
Beside the measured number, compound 3's estimate is 1.0-fold (0.01 log units) above it; measured number inside the range.
By their numbers in this assay, from the lowest: compounds 1, 3 and 2 (each within the scatter of the next).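

In this assay the step of a 1.4-fold lower number from compound 2 to compound 3 (0.14 log units; within the scatter) comes with oxan-4-yl in place of tert-butyl on the amine nitrogen in the ring, so at this position a non-aromatic ring holding an oxygen leaves the half-life within the scatter of the open-chain carbon group. Nothing measured here gives a reason for this result. Still open, going by these compounds, is whether the oxygen plays any part, which a cyclohexyl group at this nitrogen could test, and whether a group carrying an amine or a carboxylic acid there would keep the half-life in the same range.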